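Compound 4: same atoms as compound 1, configuration undrawn

The compounds below may be only part of what the source reports. "The series", "measured", "known", "first", "only" and "open" are said of these compounds alone.

Measured in a functional assay on U-87MG ATCC cells (Homo sapiens) for cytotoxicity, read by MTT assay, with a stated time of 48 h (on this read-out higher numbers stand for weaker inhibition and lower numbers for stronger inhibition), so far:
compound 1 `C/C(=N\NC(=S)Nc1ccc(Cl)cc1)c1ccccn1` gives 1.7 nM
compound 2 `C/C(=N\NC(=S)Nc1ccccc1)c1ccccn1` gives 1.4 nM
compound 3 `C/C(=N\NC(=S)Nc1ccc([N+](=O)[O-])cc1)c1ccccn1` gives 160 nM

Compound 1 stands at the low end of these numbers together with compound 2: hydrogen in place of chloro gives a 1.2-fold lower number from compound 1 to compound 2 (0.08 log units; within the scatter) here. The nitro compound stands well apart, with a 94-fold higher number from compound 1 to compound 3 (1.97 log units; beyond the scatter) and a 110-fold higher number from compound 2 to compound 3 (2.06 log units; beyond the scatter) on the same read-out.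

Next comes compound 4 `CC(=NNC(=S)Nc1ccc(Cl)cc1)c1ccccn1` in comparison with compound 1 (the two compounds have the same atoms and bonds; at least one stereo element is drawn with a configuration in one of them and without one in the other: 1 of 1 stereo elements differ; a double bond is drawn E in compound 1 and without a configuration in compound 4). Within the data shown here, none of the measured steps is of this kind: each replaces a group on an aromatic carbon, whereas here nothing leaves and nothing enters. They give no size for a double bond drawn without a configuration, and the data do not say which form of compound 4 is tested. In this assay no step beyond the scatter is therefore expected, and the estimated step is a 1.2-fold higher number from compound 1 to compound 4 (0.07 log units; within the scatter) for now. This expectation takes compound 1 at 1.7 nM as its anchor. For compound 4 the estimate is 2 nM within an expected range from 0.7 nM to 8 nM in this assay.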

Compound 4, half-maximal inhibitory concentration: 1.7 nM
The estimate for compound 4 lay 1.2-fold (0.07 log units) above the measured number, within the range that was stated.
By their numbers in this assay, from the lowest: compounds 2, 1 and 4 (each within the scatter of the next); then compound 3.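

Every other step shown replaces a group on an aromatic carbon, whereas this one sits at the double bond, where nothing leaves and nothing enters. In this assay the change from a double bond drawn E to one drawn without a configuration gives no change at the digits printed from compound 1 to compound 4 (within the scatter) and so adds no measurable size at this position. The only structural difference behind this reading lies in how the compounds are drawn: the fact that one of compounds 1 and 4 is drawn with a defined configuration and the other without, at the place where they differ.

Going by these compounds, whether compound 4 was tested as a single form or as a mixture stays open, as does the value of a form drawn Z at this double bond. Also open, on these data alone, is how a methoxy group or an amine in place of chloro on the aromatic carbon would stand against the hydrogen, chloro and nitro compounds in this assay.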